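Thiophen-2-yl for 4-(trifluoromethyl)phenyl: a step without a readable guide

The source may hold more compounds than are shown below. What is called first, only, known or untested is meant among the compounds shown, and "the series" means these compounds.

In an ADME assay on HepG2 cells (Homo sapiens) for cytotoxicity, read by MTT assay, with a stated time of 72 h (a lower number here means that less compound is tolerated, a higher number that more compound is tolerated), compound 1 (`O=[N+]([O-])c1c(CS(=O)(=O)c2ccccc2)nc2c(-c3ccc(CO)cc3)cc(Cl)cn12`) gives 13100 nM as a measured number. Compound 2 (`O=[N+]([O-])c1c(CS(=O)(=O)c2ccccc2)nc2c(-c3ccc(C(F)(F)F)cc3)cc(Cl)cn12`) gives > 3900 nM as a limit of the assay and not a number. The standing of compound 2 therefore rests on the limit of > 3900 nM in this assay, at which 1 of the 2 values shown sits, and nothing firmer.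

Compound 3 (`O=[N+]([O-])c1c(CS(=O)(=O)c2ccccc2)nc2c(-c3cccs3)cc(Cl)cn12`) carries thiophen-2-yl in place of 4-(trifluoromethyl)phenyl on an aromatic carbon of the shared core (thiophen-2-yl in place of 4-(trifluoromethyl)phenyl on an aromatic carbon). For the measured compounds named here, the only measured step is a step that the limit leaves unreadable from compound 1 to compound 2 for trifluoromethyl in place of hydroxymethyl on an aromatic carbon, and it offers neither a size nor a direction for the new change. No particular size or direction of step is therefore expected in this assay for this change.

Going by the values given here, the expectation falls back on compound 1 at 13100 nM as the one number available, with a wide range. Compound 3 is expected at 10000 nM with an estimated range from 3500 nM to 30000 nM in this read-out. The estimate means a step that the limit leaves unreadable from compound 2 to compound 3 as an expected step, read against a limit.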

Compound 3, half-maximal cytotoxic concentration: > 3900 nM
Compound 3 gave a limit, no number; the forecaster's own chance of this, stated with the estimate: 35%; the middle value is on the limit's open side.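

In this assay compound 3 gives > 3900 nM, a limit of the assay and not a number. For the compounds shown here, no step among compound 1, compound 2 and compound 3 can be read, because the comparison rests on a limit: the limit of > 3900 nM in this assay, at which 2 of the 3 values shown sit. Open remains how far, and in which direction, thiophen-2-yl in place of 4-(trifluoromethyl)phenyl moves the tolerated concentration.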